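Swapping Chloro for Methyl on the Sulfonyl Aryl

The compounds below may be only part of what the source reports. "The series", "measured", "known", "first", "only" and "open" are said of these compounds alone.

Measured so far:
- compound 1 `COc1ncc(-c2ccc3nc(NC(C)=O)nn3c2)cc1NS(=O)(=O)c1ccc(F)cc1`: 850 nM
- compound 2 `COc1ncc(-c2ccn3nc(NC(C)=O)nc3c2)cc1NS(=O)(=O)c1ccc(Cl)cc1`: 1330 nM

Two compounds with a shared core and an aryl sulfonamide have been tested in a functional assay on HCT-116 cells (Homo sapiens) for antiproliferative activity, read by MTT assay, with a stated time of 48 h; a lower number here means a stronger inhibitor, a higher number a weaker inhibitor. Compound 1 `COc1ncc(-c2ccc3nc(NC(C)=O)nn3c2)cc1NS(=O)(=O)c1ccc(F)cc1` gives 850 nM. Compound 2 `COc1ncc(-c2ccn3nc(NC(C)=O)nc3c2)cc1NS(=O)(=O)c1ccc(Cl)cc1` gives 1330 nM; this is the higher of the two numbers, yet its gap to compound 1 lies within the usual scatter, so the pair cannot be ranked.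

Compound 3 `COc1ncc(-c2ccn3nc(NC(C)=O)nc3c2)cc1NS(=O)(=O)c1ccc(C)cc1` has not been measured yet. It differs from compound 2 in one place: methyl in place of chloro on an aromatic carbon. Among the measured compounds shown here, no step between two measured compounds of this kind has been recorded, so there is no direct guide to its size. The expected step from compound 2 to compound 3 in this assay is small, a 1.1-fold higher number from compound 2 to compound 3 (0.05 log units; within the scatter), with no clear direction beyond the scatter. For compound 3 the estimated value in this assay is 1500 nM, within a range from 600 nM to 4000 nM.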

Compound 3, half-maximal inhibitory concentration: 1380 nM
Compound 3: the middle estimate sits 1.1-fold (0.04 log units) above what was measured; the measured number falls inside the stated range.
By their numbers in this assay, from the lowest: compounds 1, 2 and 3 (each within the scatter of the next).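

In this assay, the exchange of 4-chlorophenyl for 4-methylphenyl gives a 1.0-fold higher number from compound 2 to compound 3 (0.02 log units; within the scatter). Among the compounds shown here, this is the first pair that differs in one place only, so it gives the first direct reading of this position: with chloro or methyl on this aromatic carbon, para to a large group, the two compounds cannot be told apart. The data offer no measured explanation for why these two groups read alike.

For the compounds shown here, this single pair compares only two small groups, so it does not show how much variation the position can take. As far as these compounds go, whether an amine, a carboxylic acid or a longer alkyl chain at the same carbon would give a similar reading remains open.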